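This account rests on a few compounds, and the source may have more. Where it says the series, first, only, none or still open, it means among the compounds named here.

Of the compounds shown here, two bearing the shared core have been measured in an assay for inhibition of Tryptophan 2,3-dioxygenase (Homo sapiens), with stated times of 10 min and 60 min, tested at 100 uM; a higher number here means a stronger effect of the compound at the concentration tested, a lower number a weaker effect. Compound 1 `O=C(O)CNc1cccc(CNc2cc(C(F)(F)F)cc3[nH]ncc23)c1` gives 65%, while compound 2 `FC(F)(F)c1cc(NCC2CNC2)c2cn[nH]c2c1` gives 49%, the lowest of the two numbers, with compound 1 higher by a margin beyond the scatter. Compound 3 `FC(F)(F)c1cc(NCc2cccc(Br)c2)c2cn[nH]c2c1` has not yet been measured in this assay. It differs from compound 2 by 3-bromophenyl in place of azetidin-3-yl on a saturated chain carbon bound to a nitrogen on an aromatic ring. Because compound 1 , which also carries a benzylic aromatic ring on that chain carbon, reaches 65%, a rise from compound 2 to compound 3 is expected, of about a number 11 percentage points higher from compound 2 to compound 3 (beyond the scatter). Compound 3 is therefore estimated at 60%, in a range from 40% to 80%.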

Compound 3, a percentage reported as inhibition, at one concentration (the size of the read-out at that concentration, not a potency): 84%
The estimate for compound 3 lay 24 percentage points below the measured number, outside the stated range (above it).
By their numbers in this assay, from the lowest: compound 2; then compound 1; then compound 3.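

In this assay, 3-bromophenyl in place of azetidin-3-yl on the saturated chain carbon gives a number 35 percentage points higher from compound 2 to compound 3 (beyond the scatter), so this position accepts an aromatic ring of carbon only, with no hydrogen-bond donor or acceptor. Bromo in place of (carboxymethyl)amino on an aromatic carbon gives a number 19 percentage points higher from compound 1 to compound 3 (beyond the scatter), so the (carboxymethyl)amino group is not required for a high number. No measurement here accounts for either step. As far as these compounds go, whether chloro in place of bromo, or a longer chain carrying the same ring, would hold this number stays open.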